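Pyrazole Variation on the Tetrahydroquinoline Urea Amide Series

This account rests on a few compounds, and the source may have more. Where it says the series, first, only, none or still open, it means among the compounds named here.

For the measured compounds named here, compound 1 `CNC(=O)N1CCCc2ccc(NC(=O)c3ccc(-c4ccn(C)n4)cc3)cc21` gives the highest of the three numbers so far in a functional assay on MV4-11 cells (Homo sapiens) for antiproliferative activity, with a stated time of 6 days, tested at 1.56 uM (a lower number here means a weaker effect, a higher number a stronger effect of the compound at the concentration tested), with 72.2%. Compound 2 `CNC(=O)N1CCCc2ccc(NC(=O)c3cccc(-c4cn[nH]c4)c3)cc21` gives 27.9%, and compound 3 `CNC(=O)N1CCCc2ccc(NC(=O)c3cccc(-c4cnn(S(C)(=O)=O)c4)c3)cc21` gives 1.6%. Going by the values given here, the one single-point step measured so far, a number 26.3 percentage points lower from compound 2 to compound 3 (beyond the scatter), concerns a change on the pyrazole nitrogen and does not touch the change now in question.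

Compound 4 `CNC(=O)N1CCCc2ccc(NC(=O)c3ccc(-c4cn[nH]c4)cc3)cc21` differs from compound 1 as follows: 1H-pyrazol-4-yl in place of 1-methyl-1H-pyrazol-3-yl on an aromatic carbon. Among the compounds with values here, compound 2 carries the same 1H-pyrazol-4-yl group on its benzamide ring, but it is attached at a different point of that ring, so no measured step tracks the change from compound 1 to compound 4 directly. The values of compound 1 and compound 2 show that a 1H-pyrazol-4-yl bearing compound can sit well beneath compound 1 in this assay, yet the position difference leaves the bearing of that comparison uncertain.

A moderate loss is expected rather than a large one, given that compound 4 keeps the attachment point of compound 1; the expected step is a number 17.2 percentage points lower from compound 1 to compound 4 (beyond the scatter). Compound 4 is therefore estimated at 55%, within a range from 30% to 80%.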

Compound 4, a percentage reported as inhibition, at one concentration (the size of the read-out at that concentration, not a potency): 73.5%
Beside the measured number, compound 4's estimate is 18.5 percentage points below it, and the stated range covers the measured number.
By their numbers in this assay, from the lowest: compound 3; then compound 2; then compounds 1 and 4 (each within the scatter of the next).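

At the position para to a large group, a number 1.3 percentage points higher from compound 1 to compound 4 (within the scatter) in this assay, so 1H-pyrazol-4-yl and 1-methyl-1H-pyrazol-3-yl cannot be told apart here, even though the change alters the pyrazole attachment, removes the methyl group and brings in a hydrogen-bond donor together. The same 1H-pyrazol-4-yl group on compound 2, attached at a different point of the ring, gives 27.9% while compound 4 gives 73.5% in this assay, which makes the point of attachment on the ring, rather than the identity of this pyrazole, the variable that now stands out across this pair. No measurement on hand says why the two pyrazoles read alike or what separates the two attachment points.

The compounds shown leave open whether the methyl group and the pyrazole attachment each matter on their own, and 1-methyl-1H-pyrazol-4-yl at this position would separate those two parts of the change. Also open, going by these compounds, is how far the position extends beyond pyrazoles, for instance to a carboxylic acid or an aminomethyl group on the same aromatic carbon.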